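The source may report more compounds than this note shows. Statements on the series, on what has been measured and on what is new or still open speak of the compounds shown alone.

The set contains two cores. Compound 1 `C=C1C(=O)[C@]23C[C@@]1(O)CC[C@H]2c1ccc(O)c(C)c1[C@@H]3Cn1cc(-c2ccccn2)nn1` and compound 3 `C=C1C(=O)[C@]23C[C@@]1(O)CC[C@H]2c1ccc(O)c(C)c1[C@@H]3Cn1cc(-c2ccc(C(F)(F)F)cc2)nn1` share one core, while compound 2 `Cc1c(O)ccc2c1[C@H](Cn1cc(-c3ccccn3)nn1)[C@@]13CC(=O)[C@@](C)(CC[C@@H]21)C3` and compound 4 `Cc1c(O)ccc2c1[C@H](Cn1cc(-c3ccc(C(F)(F)F)cc3)nn1)[C@@]13CC(=O)[C@@](C)(CC[C@@H]21)C3` share another. The difference between the two cores is not broken down here.

In a functional assay on HL-60 cells (Homo sapiens) for cytotoxicity, read by MTT assay, with a stated time of 4 days (on this read-out higher numbers stand for weaker inhibition and lower numbers for stronger inhibition), compound 1 gives 1970 nM. In this assay compound 3 gives 720 nM. The change that separates them is 4-(trifluoromethyl)phenyl in place of pyridin-2-yl on an aromatic carbon, and it produced a 2.7-fold lower number from compound 1 to compound 3 (0.44 log units; beyond the scatter).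

For compound 2 the outcome in this assay is a limit, > 20000 nM, rather than a number. This value sits at the limit of > 20000 nM in this assay, at which 1 of the 3 values shown sits.

Compound 4 differs from compound 2 by the same change: 4-(trifluoromethyl)phenyl in place of pyridin-2-yl on an aromatic carbon. Among the compounds with values here, the change in compound 4 is thus of the same kind, on the same kind of place, as the one from compound 1 to compound 3, but it starts from a compound whose value is a limit, so where the result lands is uncertain.

Compound 4 is expected to give 15000 nM in this assay, with an estimated range from 5000 nM to 40000 nM. The estimated step of an at least 1.3-fold lower number from compound 2 to compound 4 (0.12 log units; that floor lies within the scatter) rests on the measured step of a 2.7-fold lower number from compound 1 to compound 3 (0.44 log units; beyond the scatter), carried over to the core of compound 2. Because compound 2 is known only as > 20000 nM, there is a sizeable chance that compound 4 also returns only a limit in this assay.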

Compound 4, half-maximal inhibitory concentration: > 20000 nM
Compound 4: a limit, no number (the forecaster's own chance of this, stated with the estimate: 50%); at least 1.3-fold (0.12 log units) between middle value and limit.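

In this assay compound 4 gives > 20000 nM, which is a limit of the assay and not a number. Compound 2 is likewise known only as a limit, so no step can be read between compound 2 and compound 4: the limit of > 20000 nM in this assay, at which 2 of the 4 values shown sit. The compounds shown leave open whether 4-(trifluoromethyl)phenyl in place of pyridin-2-yl shifts the value on the core of compound 2 as it does on the core of compound 1.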